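Nitro in Place of Fluoro on the Shared Core

This account rests on a few compounds, and the source may have more. Where it says the series, first, only, none or still open, it means among the compounds named here.

Compound 1 `O=C(CCl)Nc1ccc(C(=O)/C=C/c2ccc([N+](=O)[O-])cc2)cc1`: 9060 nM
Compound 2 `O=C(CSC(=S)N[C@H]1CCOC1=O)Nc1ccc(C(=O)/C=C/c2ccc(Br)cc2)cc1`: 18000 nM
Compound 3 `O=C(CSC(=S)N[C@H]1CCOC1=O)Nc1ccc(C(=O)/C=C/c2ccc(F)cc2)cc1`: > 128000 nM (a limit, not a number)

All three were tested in a functional assay on SMMC-7721 cells (Homo sapiens) for cytotoxicity, read by MTT assay, with a stated time of 72 h; on this read-out higher numbers stand for weaker inhibition and lower numbers for stronger inhibition. Compound 1 gives 9060 nM. Compound 2 gives 18000 nM. Compound 3 reaches only the limit of the assay, > 128000 nM. Compound 3 therefore stands at the weak end of the numbers shown, without an exact value of its own; the single measured step, an at least 7.1-fold higher number from compound 2 to compound 3 (0.85 log units; beyond the scatter), ends at the limit of > 128000 nM in this assay, at which 1 of the 3 values shown sits.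

Compound 4 `O=C(CSC(=S)N[C@H]1CCOC1=O)Nc1ccc(C(=O)/C=C/c2ccc([N+](=O)[O-])cc2)cc1` differs from compound 3 by nitro in place of fluoro on an aromatic carbon. Within the data shown here, no measured pair shows this exact change. Compound 1 also carries a nitro group in the same position, but its amide part is different, so its value cannot be read as a step toward compound 4. Among the measured compounds shown here, the one measured step says only that a halogen swap on this ring can move the number by a modest amount. With compound 3 beyond the limit, the direction available is downward, and a return to the range of compound 2 seems plausible, though a second limit cannot be excluded.

Compound 4 is expected to give 30000 nM, within 8000 nM to 128000 nM. The expected step is an at least 4.2-fold lower number from compound 3 to compound 4 (0.63 log units; beyond the scatter).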

Compound 4, half-maximal inhibitory concentration: > 128000 nM
Compound 4 ended at the assay's limit; the forecaster's own chance of this, stated with the estimate: 30%; middle value at least 4.2-fold (0.63 log units) away from the limit.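

In this assay, compound 4 gives > 128000 nM, which is a limit of the assay and not a number. Nitro in place of bromo on this aromatic carbon gives an at least 7.1-fold higher number from compound 2 to compound 4 (0.85 log units; beyond the scatter), so among the three groups shown here on the shared core, only bromo gives a readable value, while fluoro in compound 3 and nitro in compound 4 both end at the same limit: the limit of > 128000 nM in this assay, at which 2 of the 4 values shown sit.

The nitro group alone does not bring a readable value with it, as the longer side chain in place of the chlorine atom, with nitro kept on the ring, gives an at least 14-fold higher number from compound 1 to compound 4 (1.15 log units; beyond the scatter). The step between compound 3 and compound 4 cannot be read: both of its ends are limits.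

Going by these compounds, it remains open whether the readable value of compound 2 is special to bromo, and an amine, a methyl or a chloro group on the same aromatic carbon would help to show how narrow that requirement is. On these data alone, it is also open whether the chlorine-bearing side chain of compound 1 would keep a readable value with 4-bromophenyl or 4-fluorophenyl in place of 4-nitrophenyl.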